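A few compounds are considered here, and "the series" means these few. Any claim that something is new, unique, unknown or untested is made for them only; others in the source may bear on it.

Measured so far:
Compound 1 `COc1ccc(/C=C/c2cc(OC)cc(OC)c2/C=C/C(=O)c2ccc(C(F)(F)F)cc2)cc1`: 4.3 ug/mL
Compound 2 `COc1ccc(/C=C/c2cc(OC)cc(OC)c2/C=C/C(=O)c2ccc(Cl)cc2)cc1`: 4.9 ug/mL

Among the measured compounds shown here, in a functional assay on B16-F10 cells (Mus musculus) for antiproliferative activity, read by MTT assay, with a stated time of 48 h (a lower number here means a stronger inhibitor, a higher number a weaker inhibitor), compound 2 gives 4.9 ug/mL and stands level with compound 1 at 4.3 ug/mL, as the only comparison available is a 1.1-fold higher number from compound 1 to compound 2 (0.06 log units; within the scatter), which lies within the scatter. Compound 3 `COc1ccc(/C=C/c2cc(OC)cc(OC)c2/C=C/C(=O)c2ccccc2C)cc1` departs from compound 2 in one place: 2-methylphenyl in place of 4-chlorophenyl on a carbonyl carbon, with 2-methylphenyl in place of 4-chlorophenyl on a carbonyl carbon. For the measured compounds named here, the single measured step bears on this only in part. It exchanges chloro for trifluoromethyl on an aromatic carbon, and neither measured compound carries a 2-methylphenyl group. Going by the values given here, with only that small step as a guide, no shift beyond the scatter is expected, and the range is kept wide. The expected change is a 1.0-fold higher number from compound 2 to compound 3 (0.01 log units; within the scatter). For compound 3 the estimated value is 5 ug/mL, within an expected range of 2.5 ug/mL to 11 ug/mL.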

Compound 3, half-maximal inhibitory concentration: 6.1 ug/mL
For compound 3 the middle estimate is 1.2-fold (0.09 log units) below the measured one, and the stated range covers the measured number.
By their numbers in this assay, from the lowest: compounds 1, 2 and 3 (each within the scatter of the next).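

In this assay, 2-methylphenyl in place of 4-chlorophenyl on the carbonyl carbon gives a 1.2-fold higher number from compound 2 to compound 3 (0.10 log units; within the scatter), and 2-methylphenyl in place of 4-(trifluoromethyl)phenyl gives a 1.4-fold higher number from compound 1 to compound 3 (0.15 log units; within the scatter). Both steps stay within the scatter, so this position now holds a phenyl group carrying only carbon, with its substituent named at the 2-position rather than the 4-position, without a measurable shift from either halogen-bearing compound. Nothing available explains why these numbers stay so close.

The compounds shown cannot separate the effect of the substituent's identity from that of its place on the ring, as 4-methylphenyl and 2-chlorophenyl are not among them. They also leave open whether this position would stay within the scatter with an amine or a carboxylic acid on the phenyl ring, or with an unsubstituted phenyl group.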